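A few compounds are considered here, and "the series" means these few. Any claim that something is new, unique, unknown or untested is made for them only; others in the source may bear on it.

Of the compounds shown here, three built on one shared core have been tested in a functional assay on the whole organism for inhibition, with Cavia porcellus as the target, at a dose of 10 mg/kg by the oral route; on this read-out lower numbers stand for a weaker effect and higher numbers for a stronger effect at the one dose given. Compound 1 `COc1ccc(-c2nc(CCO)sc2-c2ccc(OC)cc2)cc1` gives 100% in this assay. Compound 2 `COC(=O)C(C)(C)c1nc(-c2ccc(OC)cc2)c(-c2ccc(OC)cc2)s1` gives 100%, and compound 3 `COc1ccc(-c2nc(CC(N)=O)sc2-c2ccc(OC)cc2)cc1` gives 100%. On these numbers compound 1 stands level with compounds 2 and 3: the step of no change at the digits printed from compound 1 to compound 2 (within the scatter) lies within the scatter, as does the step of no change at the digits printed from compound 1 to compound 3 (within the scatter), and so does the step of no change at the digits printed from compound 2 to compound 3 (within the scatter). Compound 4 `COc1ccc(-c2nc(C(F)(F)F)sc2-c2ccc(OC)cc2)cc1` has not yet been measured in this assay. It differs from compound 1 by trifluoromethyl in place of 2-hydroxyethyl on an aromatic carbon. The measured steps that bear on this change are the two that exchange the group on an aromatic carbon of the shared core, from compound 1 to compound 2 and from compound 2 to compound 3, and both were flat within the scatter. Three quite different groups at this position have thus all given the full read-out, so no step beyond the scatter is expected in this assay for the trifluoromethyl group either. The estimated step is a number 8 percentage points lower from compound 1 to compound 4 (within the scatter), which amounts to no change beyond the scatter. Compound 4 is therefore expected to give about 92% in this assay, with a range from 65% to 100%.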

Compound 4, a percentage reported as inhibition, in the whole organism at one dose (the size of the read-out at that dose, not a potency): 100%
Compound 4: middle estimate off by 8 percentage points, on the low side, within the range that was stated.
By their numbers in this assay, from the lowest: compounds 1, 2, 3 and 4 (each within the scatter of the next).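

Leaving 2-hydroxyethyl for trifluoromethyl in this assay takes away the hydrogen-bond donor and hydrogen-bond acceptor counted for the group on this aromatic carbon, and the read-out shows no change at the digits printed from compound 1 to compound 4 (within the scatter). The comparisons with the other two groups read the same, with no change at the digits printed from compound 3 to compound 4 (within the scatter) for trifluoromethyl in place of carbamoylmethyl and no change at the digits printed from compound 2 to compound 4 (within the scatter) for trifluoromethyl in place of 1-(methoxycarbonyl)-1-methylethyl, so among the compounds shown, a group with 0 hydrogen-bond donors and 0 hydrogen-bond acceptors at this position still stands level with the three earlier groups at this one dose. Nothing available explains why this position tolerates such different groups.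

As far as these compounds go, the four compounds stand level, with compound 4 at 100%, and a read-out at a single dose is not a potency, so any difference in potency among them remains open. Also open, from the compounds shown here alone, is what an amine, a carboxylic acid or a longer chain at this position would give in this assay.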